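A few compounds are considered here, and "the series" means these few. Any claim that something is new, unique, unknown or untested is made for them only; others in the source may bear on it.

Measured compounds:
Compound 1 `O=C1N=C(N2CCC[C@H]2C(=O)Nc2ccc3ncnc(Nc4cccc(Cl)c4)c3c2)S/C1=C/c1ccccc1[N+](=O)[O-]`: in a functional assay on A549 cells (Homo sapiens) for antiproliferative activity, read by MTT assay (a higher number here means a weaker inhibitor, a lower number a stronger inhibitor), compound 1 gives > 50000 nM, a limit of the assay.
Compound 2 `O=C1N=C(N2CCC[C@H]2C(=O)Nc2ccc3ncnc(Nc4cccc(Cl)c4)c3c2)S/C1=C/c1cccc(Br)c1`: compound 2 gives > 50000 nM, also a limit.
Compound 3 `COc1ccc(/C=C2/SC(N3CCC[C@H]3C(=O)Nc3ccc4ncnc(Nc5cccc(Cl)c5)c4c3)=NC2=O)cc1`: compound 3 gives 31700 nM.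

Among the compounds with values here, compound 3 stands as the only number in the set; the other two values sit at the limit of > 50000 nM in this assay, at which 2 of the 3 values shown sit. The steps of an at least 1.5-fold lower number from compound 1 to compound 3 (0.19 log units; that floor lies within the scatter) and an at least 1.5-fold lower number from compound 2 to compound 3 (0.19 log units; that floor lies within the scatter) are therefore only floors, both within the scatter, and a step that the two limits leave unreadable from compound 1 to compound 2 cannot be read. Compound 4 `O=C1N=C(N2CCC[C@H]2C(=O)Nc2ccc3ncnc(Nc4cccc(Cl)c4)c3c2)S/C1=C/c1ccccc1Cl` differs from compound 3 by 2-chlorophenyl in place of 4-methoxyphenyl on a double-bonded chain carbon bound to a double-bonded ring carbon. Within the data shown here, no measured step shows an aryl change moving the number beyond the scatter, so for compound 4 a weak value near the limit is expected, 45000 nM, ranging from 15000 nM to 120000 nM. The estimated step is a 1.4-fold higher number from compound 3 to compound 4 (0.15 log units; within the scatter), with a fair chance that only a limit is reported.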

Compound 4, half-maximal inhibitory concentration: > 50000 nM
Compound 4 gave a limit, no number; the forecaster's own chance of this, stated with the estimate: 50%; middle value at least 1.1-fold (0.04 log units) away from the limit.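

In this assay compound 4 gives > 50000 nM as a limit and not a number. The step is an at least 1.5-fold higher number from compound 3 to compound 4 (0.19 log units; that floor lies within the scatter) and shows no change beyond the scatter for 2-chlorophenyl in place of 4-methoxyphenyl, while the steps to compound 4 from compound 1 and compound 2 cannot be read. With a chlorine on the phenyl ring, the set gathers further at one limit: the limit of > 50000 nM in this assay, at which 3 of the 4 values shown sit.

Still open, on these data alone, is whether any group at this place gives a number clearly apart from that of compound 3. An amine or a carboxylic acid on the phenyl ring would test this.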